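Series notes: benzyl for cyclohexyl on the aromatic nitrogen

The source may hold more compounds than are shown below. What is called first, only, known or untested is meant among the compounds shown, and "the series" means these compounds.

Measured compounds:
compound 1, `CCc1ccc(-c2cn3ccnc3c(-c3ccc4ncn(Cc5ccccc5)c4c3)n2)cc1`, in a functional assay on EKVX cells (Homo sapiens) for inhibition, read by sulforhodamine B assay, with a stated time of 48 h, tested at 10 uM (on this read-out lower numbers stand for less inhibition and higher numbers for more inhibition at the one concentration tested (going by the name of the read-out)), compound 1 gives 39.7%.
compound 2, `c1cn2cc(-c3ccc4c(c3)ncn4C3CCCCC3)nc(-c3ccc4ncn(C5CCCCC5)c4c3)c2n1`, in this assay compound 2 gives 60.2%.

Compound 2 stands highest of the two numbers in this assay; its nearest neighbour is compound 1, whose value lies lower by a gap beyond the scatter. Within the data shown here, the two compounds differ in more than one place, so no single step between measured compounds can be drawn from them.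

Compound 3, `c1ccc(Cn2cnc3ccc(-c4nc(-c5ccc6c(c5)ncn6C5CCCCC5)cn5ccnc45)cc32)cc1`, is not yet measured in this assay. It departs from compound 2 by one change: benzyl in place of cyclohexyl on an aromatic nitrogen. The place is an aromatic nitrogen of a five-membered aromatic ring with 2 nitrogen, part of a fused system of two rings. Among the measured compounds shown here, compound 1, the only other measured compound, also carries a benzyl on such a nitrogen and sits lower in this assay, but it differs in a second place as well, so the comparison is loose.

The step from compound 2 to compound 3 in this assay is expected to be modest and downward, a number 10.2 percentage points lower from compound 2 to compound 3 (beyond the scatter), possibly within the scatter. Compound 3 is estimated at 50% in this assay, with a range from 32% to 68%.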

Compound 3, a percentage reported as inhibition, at one concentration (the size of the read-out at that concentration, not a potency): -12.3%
Compound 3: middle estimate off by 62.3 percentage points, on the high side; measured number outside the range, below it.
By their numbers in this assay, from the lowest: compound 3; then compound 1; then compound 2.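

Working notes on the series: in this assay, benzyl in place of cyclohexyl on an aromatic nitrogen gives the first single-place comparison, and the step is large: a number 72.5 percentage points lower from compound 2 to compound 3 (beyond the scatter). This position is therefore far from indifferent to the group it carries, since a single exchange of a non-aromatic carbon ring for benzyl, with the rest of compound 2 unchanged, leads to compound 3 at -12.3%, a negative reading at the one concentration tested. The finding rests on this single pair and cannot yet be extended as a pattern to other members of the series, and nothing available explains the size of the step.

The compounds shown leave open whether the drop follows the aromatic ring itself or the extra carbon that links it to the nitrogen, a question that cyclohexylmethyl or phenyl on the same nitrogen would address. Also open, on these data alone, is how an amine-bearing group such as piperidine, or a carboxylic acid on a longer chain, would read at this position, and whether the same exchange at the remaining cyclohexyl of compound 3 would give a step of similar size.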